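Neopentyl gives way to oxolan-3-yl in compound 3

A few compounds are considered here, and "the series" means these few. Any claim that something is new, unique, unknown or untested is made for them only; others in the source may bear on it.

In a physicochemical assay for lipophilicity, at pH 7.4 (on this read-out lower numbers stand for lower lipophilicity and higher numbers for higher lipophilicity), compound 1 `Cc1cc(C(=O)NCc2cccnc2)nn1Cc1cc(Cl)ccc1OCc1ccccc1` gives > 3.7, which is a limit of the assay and not a number. Compound 2 `Cc1cc(NC(=O)CC(C)(C)C)nn1Cc1cc(Cl)ccc1OCc1ccccc1` gives > 3.7, also only a limit, and so stands at the limit of > 3.7 in this assay, at which 2 of the 2 values shown sit. Compound 3 `Cc1cc(NC(=O)C2CCOC2)nn1Cc1cc(Cl)ccc1OCc1ccccc1` differs from compound 2 by oxolan-3-yl in place of neopentyl on a carbonyl carbon, with oxolan-3-yl in place of neopentyl on a carbonyl carbon. Within the data shown here, the only measured step, a step that the two limits leave unreadable from compound 1 to compound 2, offers no size to draw on. From the structural change alone, a downward move in this assay is expected, a number at least 0.10 log units lower from compound 2 to compound 3 (that floor lies within the scatter). For compound 3 the estimated value is 3.6, with an expected range from 3 to 4.2.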

Compound 3, distribution coefficient: > 3.7
Compound 3 gave a limit, no number; the forecaster's own chance of this, stated with the estimate: 35%; at least 0.10 log units between middle value and limit.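

In this assay compound 3 gives > 3.7, a limit and not a number, so the steps to compound 3 from compound 1 and compound 2 cannot be read. The compounds shown leave open whether oxolan-3-yl in place of neopentyl shifts the value in this assay at all, and all three stand at one limit: the limit of > 3.7 in this assay, at which 3 of the 3 values shown sit.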